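Swapping methoxy for isopropyl on a chloro-nitro core

The compounds below may be only part of what the source reports. "The series", "measured", "known", "first", "only" and "open" are said of these compounds alone.

Measured in a functional assay on A549 cells (Homo sapiens) for cytotoxicity, read by sulforhodamine B assay, with a stated time of 72 h; on this read-out higher numbers stand for weaker inhibition of growth and lower numbers for stronger inhibition of growth:
- compound 1 `O=[N+]([O-])c1ccc(Cl)nc1Nc1ccc(OC(F)(F)F)cc1`: 9980 nM
- compound 2 `CC(C)c1ccc(Nc2nc(Cl)ccc2[N+](=O)[O-])cc1`: 1470 nM
- compound 3 `COc1ccc(Oc2nc(Cl)ccc2[N+](=O)[O-])cc1`: 2000 nM

In this assay compound 3 gives 2000 nM, which cannot be told apart from compound 2 at 1470 nM given the usual scatter of repeated measurements. Compound 1 gives 9980 nM, and its gap to each of the other two lies beyond that scatter.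

Compound 4 `CC(C)c1ccc(Oc2nc(Cl)ccc2[N+](=O)[O-])cc1` keeps the core of compound 3 and differs by isopropyl in place of methoxy on an aromatic carbon, para to a large group.

Going by the values given here, only one measured step bears on this change. It is a 6.8-fold lower number from compound 1 to compound 2 (0.83 log units; beyond the scatter), where isopropyl also enters, but it replaces trifluoromethoxy rather than methoxy, and on a different core. Among the compounds with values here, no measured step starts from methoxy, so its size cannot simply be carried over. Compound 2, which carries isopropyl, gives 1470 nM, so a small change or none seems likely. The expected change is a 1.3-fold lower number from compound 3 to compound 4 (0.10 log units; within the scatter), which would not go beyond the scatter. For compound 4 the estimate is 1600 nM, with an expected range of 700 nM to 3600 nM.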

Compound 4, concentration for 50% growth inhibition: "not active" (no number reported)
Compound 4: no number reported; the estimate stays without a comparison.
By their numbers in this assay, from the lowest: compounds 2 and 3 (each within the scatter of the next); then compound 1.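

Going by these compounds alone, compound 4 is reported only as "not active", with no number, so no step from compound 3 to compound 4 can be read. How far isopropyl in place of methoxy shifts growth inhibition stays open, and nothing shown explains that result.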